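Oxetan-3-yl replacing butyl on the aromatic nitrogen

A few compounds are considered here, and "the series" means these few. Any claim that something is new, unique, unknown or untested is made for them only; others in the source may bear on it.

Within the data shown here, compound 1 `CCCCn1nc(C(=O)N[C@H]2COc3ccccc3N(C)C2=S)nc1Cc1ccccc1` gives 510 nM in a functional assay on HT-29 cells (Homo sapiens) for inhibition, read by luminescence and CellTiter-Glo, with a stated time of 24 h (on this read-out higher numbers stand for an effect only at larger amounts of compound and lower numbers for an effect already at smaller amounts), the lowest of the three numbers measured so far. Compound 2 `CC(C)CCn1nc(C(=O)N[C@H]2COc3ccccc3N(C)C2=S)nc1Cc1ccccc1` gives 3640 nM and compound 3 `CN1C(=S)[C@@H](NC(=O)c2nc(Cc3ccccc3)n(C3CCCCC3)n2)COc2ccccc21` gives 4000 nM; the steps of a 7.1-fold higher number from compound 1 to compound 2 (0.85 log units; beyond the scatter) and a 7.8-fold higher number from compound 1 to compound 3 (0.89 log units; beyond the scatter) both lie beyond the scatter, whereas a 1.1-fold higher number from compound 2 to compound 3 (0.04 log units; within the scatter) does not. Compound 4 `CN1C(=S)[C@@H](NC(=O)c2nc(Cc3ccccc3)n(C3COC3)n2)COc2ccccc21` differs from compound 1 by oxetan-3-yl in place of butyl on an aromatic nitrogen. Both measured departures from the butyl group, a 7.1-fold higher number from compound 1 to compound 2 (0.85 log units; beyond the scatter) and a 7.8-fold higher number from compound 1 to compound 3 (0.89 log units; beyond the scatter), raised the number, and a ring on that nitrogen is the nearer precedent, so a modest rise is expected for compound 4, with a 3.9-fold higher number from compound 1 to compound 4 (0.59 log units; beyond the scatter). Compound 4 is therefore estimated at 2000 nM, in the range 600 nM to 6500 nM.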

Compound 4, half-maximal effective concentration: 916 nM
Compound 4: middle estimate off by 2.2-fold (0.34 log units), on the high side, within the range that was stated.
By their numbers in this assay, from the lowest: compounds 1 and 4 (each within the scatter of the next); then compounds 2 and 3 (each within the scatter of the next).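

In this assay oxetan-3-yl stands level with butyl on the aromatic nitrogen, with a 1.8-fold higher number from compound 1 to compound 4 (0.25 log units; within the scatter) as the step, so this position can carry a ring without the rise seen for cyclohexyl. A ring alone does not set the number here: a 4.4-fold lower number from compound 3 to compound 4 (0.64 log units; beyond the scatter) separates two ring-bearing compounds, and a 4.0-fold lower number from compound 2 to compound 4 (0.60 log units; beyond the scatter) sets oxetan-3-yl apart from isopentyl as well.

As far as these compounds go, whether an amine, a carboxylic acid or a chain longer than butyl on this nitrogen would stay level with compound 1 remains open. No evidence at hand gives a reason for these steps.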